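A few compounds are considered here, and "the series" means these few. Any claim that something is new, unique, unknown or untested is made for them only; others in the source may bear on it.

Working notes on the series. Among the compounds with values here, in a functional assay on A549 cells (Homo sapiens) for cytotoxicity, read by MTT assay (on this read-out higher numbers stand for weaker inhibition and lower numbers for stronger inhibition), the three measured members give no single number between them. Compound 1 `CCOC(=O)c1oc2c(Br)c(OC)cc(OC)c2c1C` comes back only as a limit, > 87400 nM. Compound 2 `CCOC(=O)c1oc2c(C#N)c(OC)cc(OC)c2c1C` is reported in this assay as "not active" (no number reported), with no number attached. Compound 3 `CCOC(=O)c1oc2c(C(N)=O)c(OC)cc(OC)c2c1C` is likewise reported in this assay as "not active" (no number reported), again without a number. Compound 3 therefore stands among entries that carry no figure: of the three values shown, one sits at the limit of > 87400 nM in this assay, at which 1 of the 3 values shown sits, and the other two, compound 3 among them, are entries without a number.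

The next compound, compound 4 `CCCNC(=O)c1oc2c(C(N)=O)c(OC)cc(OC)c2c1C`, differs from compound 3 in one place: propylamino in place of ethoxy on a carbonyl carbon. Within the data shown here, no step between measured compounds is available to set the size of this change, and no measured step in this assay shows a shift beyond the scatter; none of the three entries carries a number. The expectation is for no shift beyond the scatter, with compound 4 remaining where this assay reports a limit rather than a value. Compound 4 is estimated in this assay at 100000 nM, with an expected range from 30000 nM to 300000 nM, and the most likely outcome is expected to be a limit or an entry without a number.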

Compound 4, half-maximal inhibitory concentration: > 93600 nM
Compound 4: no number, only a limit (the forecaster's own chance of this, stated with the estimate: 85%); the middle value is on the limit's open side.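

In this assay compound 4 gives > 93600 nM, which is a limit and not a number. Within the data shown here, compound 3 carries no number, so no step from compound 3 to compound 4 can be read. The compounds shown leave open whether propylamino in place of ethoxy on a carbonyl carbon shifts the read-out at all.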